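The source may hold more compounds than are shown below. What is called first, only, known or untested is meant among the compounds shown, and "the series" means these compounds.

In an assay on isolated protein with Bile acid receptor (Homo sapiens) as the target (on this read-out lower numbers stand for an effect already at smaller amounts and higher numbers for an effect only at larger amounts of compound), compound 1 `COC(=O)/C=C/c1cccc(N(Cc2ccc(-c3c(OC)cccc3OC)cc2)C(=O)C2CCCCC2)c1` gives 77 nM. Compound 2 `COC(=O)/C=C/c1cccc(N(Cc2ccc(C(C)(C)C)cc2)C(=O)C2CCCCC2)c1` reaches only a limit of the assay, > 1000 nM. Compound 3 `COC(=O)/C=C/c1cccc(N(Cc2ccc(/C=C/C(=O)N(C)C)cc2)C(=O)C2CCCCC2)c1` likewise stops at a limit, > 1000 nM, so its place among the numbers shown is known only as that boundary. Two of the three values sit there: the limit of > 1000 nM in this assay, at which 2 of the 3 values shown sit. Compound 4 `COC(=O)/C=C/c1cccc(N(Cc2ccc(-c3cc(Cl)ccc3OC)cc2)C(=O)C2CCCCC2)c1` differs from compound 3 in one place (5-chloro-2-methoxyphenyl in place of 2-(dimethylcarbamoyl)ethenyl on an aromatic carbon). Going by the values given here, the steps that bear on this are an at least 12-fold higher number from compound 1 to compound 3 (1.11 log units; beyond the scatter) and an at least 12-fold higher number from compound 1 to compound 2 (1.11 log units; beyond the scatter), while a step that the two limits leave unreadable from compound 2 to compound 3. Since compound 1, carrying a similar aryl group, gives 77 nM, a large downward step is expected, an at least 6.6-fold lower number from compound 3 to compound 4 (0.82 log units; beyond the scatter). Compound 4 is therefore estimated at 150 nM, within 50 nM to 600 nM.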

Compound 4, half-maximal effective concentration: 233 nM
Estimate against measurement, compound 4: 1.6-fold (0.19 log units) below; the range from low to high includes it.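

In this assay, a second substituted phenyl group on this aromatic carbon also gives a readable value, with an at least 4.2-fold lower number from compound 3 to compound 4 (0.63 log units; beyond the scatter) and an at least 4.2-fold lower number from compound 2 to compound 4 (0.63 log units; beyond the scatter). The two phenyl groups do not give the same result: with 5-chloro-2-methoxyphenyl in place of 2,6-dimethoxyphenyl there is a 3.0-fold higher number from compound 1 to compound 4 (0.48 log units; beyond the scatter), so the groups on that ring matter too. The first two steps give only minimum sizes, and compounds 2 and 3 stay at a limit: the limit of > 1000 nM in this assay, at which 2 of the 4 values shown sit.

Going by these compounds, whether a plain phenyl or a pyridine ring would also give a readable value remains open. So does how much of the step from compound 1 comes from the chlorine and how much from the methoxy groups.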